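Shortening the ketone side chain in an mGlu2 modulator series

A few compounds are considered here, and "the series" means these few. Any claim that something is new, unique, unknown or untested is made for them only; others in the source may bear on it.

Measured compounds:
compound 1 `CCCC(=O)c1ccc(OCCCCOc2cc(C(=O)O)ccc2OC)c(C)c1O` — 82.8%
compound 2 `COc1ccc(C(=O)O)cc1OCCCCOc1ccc(C(=O)C(C)C)c(O)c1C` — 66.6%
compound 3 `COc1ccc(C(=O)O)cc1OCCCCOc1ccc(C(=O)CC2CCCC2)c(O)c1C` — 91.8%

In an assay on HEK293 cells for positive allosteric modulation of metabotropic glutamate receptor 2 (Rattus norvegicus), read by thallium flux, with a stated time of 2.5 min (a higher number here means a larger maximal response, a lower number a smaller maximal response), compound 3 gives 91.8%. Its number sits well apart from compound 2, with a number 25.2 percentage points higher from compound 2 to compound 3 (beyond the scatter), whereas against compound 1 the gap is a number 9 percentage points higher from compound 1 to compound 3 (within the scatter), so these two cannot be told apart. Compound 4 `COc1ccc(C(=O)O)cc1OCCCCOc1ccc(C(C)=O)c(O)c1C` differs from compound 3 by hydrogen in place of cyclopentyl on a saturated chain carbon bound to a carbonyl carbon. Within the data shown here, no measured step covers this change directly. The step from compound 1 to compound 3, a number 9 percentage points higher from compound 1 to compound 3 (within the scatter), shows that trading ethyl for cyclopentyl on that chain carbon hardly moves the read-out, while the step from compound 1 to compound 2, a number 16.2 percentage points lower from compound 1 to compound 2 (beyond the scatter), shows that a changed ketone substituent can lower the maximal response by a modest amount. Compound 4 carries the smallest group of the four at this position, so a modest decrease, possibly beyond the scatter, is expected, a number 16.8 percentage points lower from compound 3 to compound 4 (beyond the scatter). Compound 4 is estimated at 75%, within a range from 55% to 95%.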

Compound 4, largest response reached (reported as percent of maximum), in percent of the reference or control that the assay uses: 70.7%
Compound 4: the middle estimate sits 4.3 percentage points above what was measured; measured number inside the range.
By their numbers in this assay, from the lowest: compounds 2 and 4 (each within the scatter of the next); then compounds 1 and 3 (each within the scatter of the next).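

Shortening the side chain to acetyl does lower the response: a number 21.1 percentage points lower from compound 3 to compound 4 (beyond the scatter), and a number 12.1 percentage points lower from compound 1 to compound 4 (beyond the scatter), so the tolerance seen between ethyl and cyclopentyl on the saturated chain carbon bound to a carbonyl carbon does not extend to hydrogen there. Methyl and isopropyl on the carbonyl carbon cannot be told apart, with a number 4.1 percentage points higher from compound 2 to compound 4 (within the scatter), which places compound 2 and compound 4 together as a lower pair, beneath compound 1 and compound 3. Nothing measured here explains why the response divides in this way.

The compounds shown leave open whether a longer chain on the carbonyl carbon, such as hexyl, would keep the response of compound 3. They also do not show how an amine or a hydroxyl on that saturated chain carbon would compare.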